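Working notes: isopropyl in place of methyl

The source may report more compounds than this note shows. Statements on the series, on what has been measured and on what is new or still open speak of the compounds shown alone.

Measured in a functional assay on HeLa cells (Homo sapiens); on this read-out lower numbers stand for stronger inhibition and higher numbers for weaker inhibition:
- compound 1 `O=C(O)CSC(CC(=O)c1ccccc1)C(=O)O` gives 15000 nM
- compound 2 `Cc1ccc(C(=O)CC(SCC(=O)O)C(=O)O)cc1` gives 17300 nM

Compound 2 sits within the scatter of compound 1, and these two numbers are all that is measured so far. Compound 3 `CC(C)c1ccc(C(=O)CC(SCC(=O)O)C(=O)O)cc1` differs from compound 2 as follows: isopropyl in place of methyl on an aromatic carbon. Going by the values given here, the only measured step bearing on this is a 1.2-fold higher number from compound 1 to compound 2 (0.06 log units; within the scatter), methyl in place of hydrogen on an aromatic carbon. With that single small step as the guide, no change beyond the scatter is expected in this assay. The expected step is a 1.0-fold lower number from compound 2 to compound 3 (0.01 log units; within the scatter). For compound 3 the estimate is 17000 nM, with an estimated range of 8000 nM to 38000 nM.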

Compound 3, half-maximal inhibitory concentration: 3330 nM
Estimate against measurement, compound 3: 5.1-fold (0.71 log units) above; measured number below the stated range.
By their numbers in this assay, from the lowest: compound 3; then compounds 1 and 2 (each within the scatter of the next).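

This position is not neutral in this assay: isopropyl in place of methyl gives a 5.2-fold lower number from compound 2 to compound 3 (0.72 log units; beyond the scatter) and isopropyl in place of hydrogen gives a 4.5-fold lower number from compound 1 to compound 3 (0.65 log units; beyond the scatter), while methyl in place of hydrogen gave only a 1.2-fold higher number from compound 1 to compound 2 (0.06 log units; within the scatter). Among these compounds, a step beyond the scatter appears only with isopropyl, the group of 3 heavy atoms. Nothing available accounts for this gain. Open, from the compounds shown here alone, is whether a tert-butyl group or a longer chain such as n-butyl goes further. Also open, going by these compounds, is whether a methoxy group or an amine at this position keeps the gain.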